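Benzyl in Place of Methyl on the Aromatic Nitrogen

The source may hold more compounds than are shown below. What is called first, only, known or untested is meant among the compounds shown, and "the series" means these compounds.

Measured compounds:
Compound 1, `N#Cc1c(-c2ccc(Cl)cc2)nc(SCC(=O)Nn2c(COc3ccc(Cl)cc3Cl)nc3ccccc3c2=O)[nH]c1=O`, gives 63.6% in a functional assay on the whole organism (strain albino) for inhibition, with Rattus norvegicus as the target, read by paw edema, with a stated time of 1 h, at a dose of 100 mg/kg by the oral route; on this read-out higher numbers stand for more inhibition at the one dose given (going by the name of the read-out) and lower numbers for less inhibition.
Compound 2, `N#Cc1c(-c2ccccc2)nc(SCC(=O)Nn2c(COc3ccc(Cl)cc3Cl)nc3ccccc3c2=O)n(Cc2ccccc2)c1=O`, gives 77.3%.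
Compound 3, `Cn1c(SCC(=O)Nn2c(COc3ccc(Cl)cc3Cl)nc3ccccc3c2=O)nc(-c2ccc(Cl)cc2)c(C#N)c1=O`, gives 76.4%.

Compound 3 stands second highest of the three numbers in this assay: compound 2 lies a little higher, within the scatter, and compound 1 lies lowest, beyond the scatter. For the measured compounds named here, the only step between compounds that differ in a single place is a number 12.8 percentage points higher from compound 1 to compound 3 (beyond the scatter), methyl in place of hydrogen on an aromatic nitrogen, a modest rise.

Compound 4, `N#Cc1c(-c2ccc(Cl)cc2)nc(SCC(=O)Nn2c(COc3ccc(Cl)cc3Cl)nc3ccccc3c2=O)n(Cc2ccccc2)c1=O`, differs from compound 3 by phenyl in place of hydrogen on a saturated chain carbon bound to an aromatic nitrogen, so it carries the benzyl group also present in compound 2 while the rest of compound 3 is kept. Going by the values given here, no measured step isolates this exact change; compound 2 and compound 3 differ in two places, and their values lie within the scatter of each other. Among the compounds with values here, the rise from compound 1 to compound 3 shows that substitution on this nitrogen has so far gone with higher inhibition, but the growth from methyl to benzyl has no single-step precedent here. The step of a number 0.6 percentage points higher from compound 3 to compound 4 (within the scatter) is therefore expected to stay within the scatter. The estimate for compound 4 is 77%, between 66% and 86%.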

Compound 4, a percentage reported as inhibition, in the whole organism at one dose (the size of the read-out at that dose, not a potency): 72.7%
Estimate against measurement, compound 4: 4.3 percentage points above, within the range that was stated.
By their numbers in this assay, from the lowest: compounds 1, 4, 3 and 2 (each within the scatter of the next, the first and the last beyond it).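

In this assay the growth from methyl to benzyl on the aromatic nitrogen, phenyl in place of hydrogen on a saturated chain carbon bound to an aromatic nitrogen, gives a number 3.7 percentage points lower from compound 3 to compound 4 (within the scatter) and so cannot be told from scatter, which means this position holds the larger group with no measurable change in inhibition. Benzyl in place of hydrogen on the aromatic nitrogen gives a number 9.1 percentage points higher from compound 1 to compound 4 (within the scatter) while methyl in the same place gave a number 12.8 percentage points higher from compound 1 to compound 3 (beyond the scatter) and thus only the methyl step clears the scatter, yet the two substituted compounds cannot be separated from each other. Chloro in place of hydrogen on an aromatic carbon, now seen on its own, gives a number 4.6 percentage points lower from compound 2 to compound 4 (within the scatter) and is likewise unresolved, and nothing at hand explains any of these numbers.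

The compounds shown leave open how a longer alkyl chain, or a chain ending in an amine or a carboxylic acid, would read on this nitrogen, and whether a methoxy group in place of the chloro would move the number. On these data alone, all readings stand at a single dose, so how these compounds would rank across doses also remains open.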